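N-aryl swap on the pyrazole core: from anisyl to pyridyl

The compounds below may be only part of what the source reports. "The series", "measured", "known", "first", "only" and "open" are said of these compounds alone.

Measured so far in an assay on HEK293 cells for inhibition of Voltage-dependent N-type calcium channel subunit alpha-1B (Homo sapiens), read by patch clamp, using a membrane potential dye; a higher number here means a weaker inhibitor, a lower number a stronger inhibitor:
- compound 1 `COc1ccccc1-n1nc(C2CC(C)(C)OC(C)(C)C2)cc1-c1ccc(Cl)cc1`: 16 nM
- compound 2 `COc1ccccc1-n1nc(C2CC(C)(C)OC(C)(C)C2)cc1-c1ccc(C)nc1`: 13000 nM
- compound 3 `COc1ccccc1-n1nc(C2CCOC(C)(C)C2)cc1-c1ccc(Cl)cc1`: 55 nM

Compound 1 gives the lowest number of the three. Compound 3 sits nearest, with a 3.4-fold higher number from compound 1 to compound 3 (0.54 log units; beyond the scatter), a modest step. Compound 2 lies furthest away, with an 810-fold higher number from compound 1 to compound 2 (2.91 log units; beyond the scatter), a large step.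

Compound 4 `CC1(C)CC(c2cc(-c3ccc(Cl)cc3)n(-c3ccncc3)n2)CC(C)(C)O1` is not yet measured. It differs from compound 1 at the aromatic nitrogen of the shared core: pyridin-4-yl in place of 2-methoxyphenyl on an aromatic nitrogen.

Within the data shown here, neither measured step touches this position, so there is no direct precedent. The step from compound 1 to compound 2 is the only one in which a phenyl ring gives way to a pyridin-yl ring, and there the number rose sharply; the step to compound 3 shows that a smaller change elsewhere on the core costs only a modest amount. Among the measured compounds shown here, with no step at the nitrogen itself, a weaker inhibition than compound 1 is expected but its size is uncertain, and the estimate leans toward a clear loss with a wide range, a 16-fold higher number from compound 1 to compound 4 (1.19 log units; beyond the scatter).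

For compound 4 the expected value in this assay is 250 nM, with a range from 40 nM to 2500 nM.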

Compound 4, half-maximal inhibitory concentration: 22000 nM
Beside the measured number, compound 4's estimate is 88-fold (1.94 log units) below it, and the stated range ends below it.
By their numbers in this assay, from the lowest: compound 1; then compound 3; then compounds 2 and 4 (each within the scatter of the next).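

The aromatic nitrogen of the shared core now has a direct reading in this assay: pyridin-4-yl in place of 2-methoxyphenyl gives a 1400-fold higher number from compound 1 to compound 4 (3.14 log units; beyond the scatter), a large step that shows the potency of compound 1 depends strongly on the group at this position. The step is of the same large class as the one at the aromatic carbon, an 810-fold higher number from compound 1 to compound 2 (2.91 log units; beyond the scatter), so in these two compounds a large loss follows when a six-membered aromatic ring of carbon only gives way to a pyridinyl ring at either place, whereas the change on the oxane in a 3.4-fold higher number from compound 1 to compound 3 (0.54 log units; beyond the scatter) remains modest. Nothing available explains the size of this loss.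

Among these compounds, the single step removes the methoxy group and brings in the ring nitrogen together, so the share of each in the loss stays open; a plain phenyl ring and 2-methoxypyridin-3-yl on the same aromatic nitrogen would separate the two. Also open, going by these compounds, is whether any pyridinyl ring can be held at this position, for instance pyridin-3-yl or pyridin-2-yl in place of pyridin-4-yl.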